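The compounds below may be only part of what the source reports. "The series", "measured", "known", "first", "only" and "open" are said of these compounds alone.

Measured compounds:
compound 1, `Cn1cncc1C(OCc1ccc(C#N)cc1-c1ccccc1)c1ccc(C#N)cc1`, 140 nM
compound 2, `Cn1cncc1C(OCc1ccc(C#N)cc1C#Cc1ccc(C#N)cc1)c1ccc(C#N)cc1`, 11.6 nM
compound 3, `Cn1cncc1C(OCc1ccc(C#N)cc1C#CC1(O)CCCCC1)c1ccc(C#N)cc1`, 1.93 nM

In a functional assay on NIH3T3 cells (Mus musculus) (a lower number here means that less compound is needed, a higher number that more compound is needed for the effect), compound 1 stands highest of the three numbers, so of these compounds it needs the most material for the effect. The unmeasured compound 4, `CCCCCCC#Cc1cc(C#N)ccc1COC(c1ccc(C#N)cc1)c1cncn1C`, differs from compound 1 in one place: oct-1-yn-1-yl in place of phenyl on an aromatic carbon. Within the data shown here, two measured steps bear on this change, since each also replaces the phenyl on that aromatic carbon with a group carrying a triple bond: a 12-fold lower number from compound 1 to compound 2 (1.08 log units; beyond the scatter) and a 73-fold lower number from compound 1 to compound 3 (1.86 log units; beyond the scatter). The step of a 6.0-fold lower number from compound 2 to compound 3 (0.78 log units; beyond the scatter) shows that the group at the far end of the triple bond matters as well. Among the measured compounds shown here, compound 4 carries a plain chain there, with no ring, so no measured compound tells directly how that end behaves. A large step downward is therefore expected, likely of a size between the two measured ones. For compound 4 the expected value in this assay is 15 nM, with a range from 4 nM to 50 nM. This corresponds to an expected step of a 9.3-fold lower number from compound 1 to compound 4 (0.97 log units; beyond the scatter).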

Compound 4, half-maximal effective concentration: > 0.1 nM
Compound 4 gave a limit, no number; the forecaster's own chance of this, stated with the estimate: 2%; the middle value is on the limit's open side.
By their numbers in this assay, from the lowest: compound 3; then compound 2; then compound 1.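

Compound 4 gave a limit and not a number: the limit of > 0.1 nM in this assay, at which 1 of the 4 values shown sits. The steps to compound 4 from compound 1, compound 2 and compound 3 cannot be read. The compounds shown leave open how compound 4, with its oct-1-yn-1-yl chain, ranks against these three.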